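This account rests on a few compounds, and the source may have more. Where it says the series, first, only, none or still open, it means among the compounds named here.

Measured compounds:
compound 1 `COc1cc(/C=C/C(=O)c2cc3cc(O)ccc3oc2=O)cc(OC)c1OC`: 3900 nM
compound 2 `COc1cccc(COc2ccc3cc(C(=O)/C=C/c4ccc(C)cc4)c(=O)oc3c2)c1`: > 50000 nM

In a functional assay on MOLT-4 cells (Homo sapiens) for cytotoxicity, read by MTT assay, with a stated time of 72 h (on this read-out higher numbers stand for weaker inhibition and lower numbers for stronger inhibition), compound 1 gives 3900 nM, the only number shown in this set. Compound 2 reports only a limit in this assay, > 50000 nM (the limit of > 50000 nM in this assay, at which 1 of the 2 values shown sits). Compound 3 `COc1cc(/C=C/C(=O)c2cc3cc(OCc4ccccc4)ccc3oc2=O)cc(OC)c1OC` is compound 1 with benzyl in place of hydrogen on an oxygen on an aromatic ring. Going by the values given here, no measured pair covers this change, so the step from compound 1 to compound 3 is an expectation only: a weakening in this assay that is expected to exceed the scatter, a 3.8-fold higher number from compound 1 to compound 3 (0.59 log units; beyond the scatter). Compound 3 is therefore estimated at 15000 nM, with a range from 4000 nM to 50000 nM.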

Compound 3, half-maximal inhibitory concentration: 10300 nM
Estimate against measurement, compound 3: 1.5-fold (0.16 log units) above, and the stated range covers the measured number.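

In this assay, going by these compounds alone, hydroxy to benzyloxy on the aromatic ring gives a 2.6-fold higher number from compound 1 to compound 3 (0.42 log units; beyond the scatter), the only measured step at this position. This oxygen therefore accepts a benzyl group at a modest loss, and compound 3 still gives a number rather than a limit. Nothing shown gives a cause for this step.

Open, from the compounds shown here alone, is whether a smaller methyl group on this oxygen would stay closer to compound 1. Also open, going by these compounds, is how a chain ending in an amine or a carboxylic acid would read here.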